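This account rests on a few compounds, and the source may have more. Where it says the series, first, only, none or still open, it means among the compounds named here.

Measured so far:
compound 1, `CC(C)OC(=O)N1CCC(COc2ccc(N3CCN(C(=O)c4ccco4)CC3)nc2)CC1`, gives 1900 nM in a functional assay on CHO-K1 cells for agonist activity at Glucose-dependent insulinotropic receptor (Homo sapiens), read by a luciferase reporter, with a stated time of 5 h; a higher number here means that more compound is needed for the effect, a lower number that less compound is needed.
compound 2, `CC(C)OC(=O)N1CCC(COc2ccc(N3CCN(S(=O)(=O)c4cccnc4)CC3)nc2)CC1`, gives 2000 nM in this assay.

Going by the values given here, on these two numbers compound 2 has the higher value, but the difference to compound 1 is tiny: the one measured step, a 1.1-fold higher number from compound 1 to compound 2 (0.02 log units; within the scatter), lies within the scatter, so the two cannot be ranked. That step swapped the group on the amine nitrogen in the ring from (furan-2-yl)carbonyl to (pyridin-3-yl)sulfonyl and left the number essentially unchanged.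

Compound 3, `CCN(CC)S(=O)(=O)N1CCN(c2ccc(OCC3CCN(C(=O)OC(C)C)CC3)cn2)CC1`, is the next variation at the same end of the molecule: diethylamino in place of pyridin-3-yl on a sulfonyl sulfur. The sulfonyl and the ring-bound sulfonamide nitrogen stay; only the piece beyond the sulfur changes.

Among the compounds with values here, the only step that bears on this is the one from compound 1 to compound 2, and it was flat. That gives no reason to expect a large shift in either direction, though a change from an aromatic ring to a diethylamino group is a different kind of swap, so the outcome is uncertain. The expected step is a 1.3-fold higher number from compound 2 to compound 3 (0.10 log units; within the scatter), a small rise within the scatter. Compound 3 is therefore estimated at 2500 nM in this assay, with a range from 800 nM to 8000 nM.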

Compound 3, half-maximal effective concentration: 1200 nM
The estimate for compound 3 lay 2.1-fold (0.32 log units) above the measured number, and the stated range covers the measured number.
By their numbers in this assay, from the lowest: compounds 3, 1 and 2 (each within the scatter of the next).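

In this assay the piece on the sulfonyl sulfur can be an open diethylamino group as well as an aromatic pyridin-3-yl ring: this swap gives a 1.7-fold lower number from compound 2 to compound 3 (0.22 log units; within the scatter), so at this position the ring is not needed to keep the number within the scatter. The broader change on the amine nitrogen in the ring, diethylsulfamoyl in place of (furan-2-yl)carbonyl, gives a 1.6-fold lower number from compound 1 to compound 3 (0.20 log units; within the scatter), so all three groups shown here, with or without a ring and on a carbonyl or a sulfonyl, cannot be told apart by this read-out. Nothing measured here speaks to the reason for this flat picture.

The compounds shown leave open whether a free amine, a carboxylic acid or a longer chain on the sulfonyl sulfur would move the number beyond the scatter, in either direction. All three also share the rest of the molecule, so they cannot tell whether this end would stay as flat if the shared core were changed elsewhere.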